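The source may report more compounds than this note shows. Statements on the series, on what has been measured and on what is new or still open speak of the compounds shown alone.

Of the compounds shown here, two built on a shared core have been measured in a functional assay on HBL-100 cells (Homo sapiens) for inhibition, read by sulforhodamine B assay, with a stated time of 48 h; a lower number here means a stronger inhibitor of growth, a higher number a weaker inhibitor of growth. Compound 1 `COC(=O)[C@@]1(C)CCC=C2[C@@H]1CC[C@@H](C)[C@]2(C)Cc1c[nH]c2c(C)cccc12` gives 8000 nM. Compound 2 `COC(=O)[C@@]1(C)CC[C@@H]2C3=C1CC[C@@H](C)[C@]3(C)C[C@@H]1c3ccccc3N[C@H]21` gives 78000 nM, the higher of the two numbers, so compound 2 is the weaker growth inhibitor of the pair. Compound 3 `COC(=O)[C@@]1(C)CC[C@@H]2C3=C1CC[C@@H](C)[C@]3(C)C[C@@H]1c3cc(Br)ccc3N[C@H]21` differs from compound 2 in a single place: bromo in place of hydrogen on an aromatic carbon. For the measured compounds named here, no measured pair shows this exchange on this core, so its effect is unknown; a step of modest size is expected, possibly toward a lower number, possibly none beyond the scatter. Compound 3 is estimated at 50000 nM, between 15000 nM and 150000 nM. The expected step is a 1.6-fold lower number from compound 2 to compound 3 (0.19 log units; within the scatter).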

Compound 3, concentration for 50% growth inhibition: 34000 nM
For compound 3 the middle estimate is 1.5-fold (0.17 log units) above the measured one; low and high end bracket the measured number.
By their numbers in this assay, from the lowest: compound 1; then compound 3; then compound 2.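

Bromo in place of hydrogen on this aromatic carbon gives a 2.3-fold lower number from compound 2 to compound 3 (0.36 log units; beyond the scatter) and so, though modest, the step is a real gain in growth inhibition. A single added heavy atom is thus tolerated at this spot, meta to a fused ring and para to a fused ring. Nothing available explains the change.

As far as these compounds go, whether this gain is specific to bromo remains open, since a chloro, methoxy or amine group on the same carbon would test that. The effect of bromo at other carbons of this ring is also unknown.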